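Reading a Swap on the Outer Ring

The source may report more compounds than this note shows. Statements on the series, on what has been measured and on what is new or still open speak of the compounds shown alone.

Values so far in a functional assay on Gurav cells (Homo sapiens) for inhibition, read by sulforhodamine B assay; on this read-out lower numbers stand for stronger inhibition of growth and higher numbers for weaker inhibition of growth
Compound 1 `COc1cc(-c2ccc(-c3ccc(-c4nc5cc(C)ccc5[nH]4)cc3)cc2)cc(OC)c1OC` gives 170 nM
Compound 2 `FC(F)(F)c1ccc(-c2ccc(-c3ccc(-c4nc5ccccc5[nH]4)cc3)cc2)cc1` gives 39100 nM

Of these two numbers, compound 2 holds the higher at 39100 nM, so it shows the weaker inhibition of growth, and the gap to compound 1 lies well beyond the scatter. Compound 3 `CN(C)c1ccc(-c2ccc(-c3ccc(-c4nc5ccccc5[nH]4)cc3)cc2)cc1` has not been measured. It carries dimethylamino in place of trifluoromethyl on an aromatic carbon, para to a large group (dimethylamino in place of trifluoromethyl on an aromatic carbon). Going by the values given here, no measured pair shows what this swap does. Compound 2 differs from compound 1 in more than one place, so the reading for compound 1, 170 nM, offers only loose guidance. A move to a lower number, beyond the scatter, is still expected, with an estimated size of a 9.8-fold lower number from compound 2 to compound 3 (0.99 log units; beyond the scatter). For compound 3 the estimated value is 4000 nM, with an expected range from 500 nM to 30000 nM.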

Compound 3, concentration for 50% growth inhibition: 100000 nM
Beside the measured number, compound 3's estimate is 25-fold (1.40 log units) below it, and the stated range ends below it.
By their numbers in this assay, from the lowest: compound 1; then compound 2; then compound 3.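

In this assay, putting dimethylamino in place of trifluoromethyl, on an aromatic carbon para to a large group, brings a 2.6-fold higher number from compound 2 to compound 3 (0.41 log units; beyond the scatter), a modest move toward weaker inhibition of growth. Going by these compounds alone, this is the first direct reading of this position: the rest of the molecule stays the same, so the step belongs to this one swap, and dimethylamino does not lower the number here. No measurement at hand gives a reason for the rise.

A single step cannot show how other groups at this position would behave, such as a carboxylic acid, a nitrile or a primary amine. On these data alone, compound 1 differs from compound 2 in more than one place, so which of those differences goes with its lower number also stays open.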